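A 3-(trifluoromethyl)phenyl amide in place of 4-iodophenyl

The source may report more compounds than this note shows. Statements on the series, on what has been measured and on what is new or still open speak of the compounds shown alone.

In a functional assay on MCF7 cells (Homo sapiens) for inhibition, read by MTT assay (on this read-out lower numbers stand for stronger inhibition and higher numbers for weaker inhibition), compound 1 (`COc1cc2ncnc(Nc3ccc(NC(=O)c4ccccc4C)cc3)c2cc1OC`) gives 21000 nM while compound 2 (`COc1cc2ncnc(Nc3ccc(NC(=O)c4ccc(Cl)cc4)cc3)c2cc1OC`) gives 30000 nM and compound 3 (`COc1cc2ncnc(Nc3ccc(NC(=O)c4ccc(I)cc4)cc3)c2cc1OC`) gives 48000 nM on the same read-out. Compound 3 stands clear of only one of the other two: a 2.3-fold higher number from compound 1 to compound 3 (0.36 log units; beyond the scatter) sets it apart, whereas a 1.6-fold higher number from compound 2 to compound 3 (0.20 log units; within the scatter) does not.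

Compound 4 (`COc1cc2ncnc(Nc3ccc(NC(=O)c4cccc(C(F)(F)F)c4)cc3)c2cc1OC`) has still to be measured in this assay and differs from compound 3 in one place. The change is 3-(trifluoromethyl)phenyl in place of 4-iodophenyl on a carbonyl carbon with 3-(trifluoromethyl)phenyl in place of 4-iodophenyl on a carbonyl carbon. For the measured compounds named here, no measured compound carries this group, so only the steps at that same carbonyl carbon bear on it. These are a 1.4-fold higher number from compound 1 to compound 2 (0.15 log units; within the scatter) and a 2.3-fold higher number from compound 1 to compound 3 (0.36 log units; beyond the scatter) and neither is large. They offer no firm direction for the new group, and a step of similarly small size, most likely within the scatter, is therefore expected. The estimated step is a 1.5-fold lower number from compound 3 to compound 4 (0.16 log units; within the scatter) with the estimate placed among the three measured values. Compound 4 is expected at 33000 nM with an estimated range from 14000 nM to 75000 nM on this reasoning.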

Compound 4, half-maximal inhibitory concentration: > 100000 nM
Compound 4 was reported as a limit; the forecaster's own chance of this, stated with the estimate: 10%; at least 3.0-fold (0.48 log units) between middle value and limit.
By their numbers in this assay, from the lowest: compounds 1, 2 and 3 (each within the scatter of the next, the first and the last beyond it). At a limit, above all of these: compound 4.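

In this assay compound 4 is recorded as a limit and not as a number: the limit of > 100000 nM in this assay, at which 1 of the 4 values shown sits.

Even read as a limit, it gives an at least 2.0-fold higher number from compound 3 to compound 4 (0.31 log units; beyond the scatter) and an at least 3.3-fold higher number from compound 2 to compound 4 (0.52 log units; beyond the scatter) and also an at least 4.7-fold higher number from compound 1 to compound 4 (0.67 log units; beyond the scatter), all three beyond the scatter. The change at this carbonyl carbon therefore separates compound 4 from every other amide shown, whereas compound 1 and compound 3 each stood clear of only one other compound, and compound 2 of neither. The earlier compounds shown here left open whether this position could move the read-out much beyond the range they spanned, and the 3-(trifluoromethyl)phenyl group shows that replacing the aromatic group on the carbonyl carbon can carry it to the limit of the assay.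

What remains open is whether this result belongs to the trifluoromethyl group itself or to where it sits, since no compound shown carries that group in another place or another group in the same place. Also open, as far as these compounds go, is how this assay would respond to an amine or a carboxylic acid on this phenyl ring, or to a cyclohexyl group in its stead.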